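Trading a Pentyloxy Chain for a Chlorine Atom

This account rests on a few compounds, and the source may have more. Where it says the series, first, only, none or still open, it means among the compounds named here.

Two cytotoxic sulfoxide-bearing compounds set the frame for this account. Compound 1 `CCCCCOc1ccc2oc(/C=C/[S+](C)[O-])cc(=O)c2c1` carries a pentyloxy chain on its aromatic ring; in a functional assay on DLD-1 cells (Homo sapiens) for cytotoxicity, with a stated time of 48 h (a higher number here means a weaker inhibitor, a lower number a stronger inhibitor), compound 1 gives 6600 nM. Compound 2 `Cc1c(/C=C/[S+](C)[O-])oc2ccccc2c1=O` has a different substitution pattern on the shared core, and in this assay compound 2 gives 7200 nM. The two numbers sit within the usual scatter of each other, so compound 1 cannot be set apart from compound 2 on these data; neither is the stronger or weaker inhibitor of the pair.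

Compound 3 `C[S+]([O-])/C=C/c1cc(=O)c2cc(Cl)ccc2o1` is not yet measured. It differs from compound 1 in one place: chloro in place of pentyloxy on an aromatic carbon. Within the data shown here, no measured pair shows what such a swap does, so the expectation rests only on the narrow spread of the two known values. Compound 3 is expected to land close to compound 1, with a step from compound 1 to compound 3 of a 1.1-fold higher number from compound 1 to compound 3 (0.03 log units; within the scatter), which is not expected to exceed the scatter. For compound 3 the estimate in this assay is 7000 nM, with a likely range from 2500 nM to 20000 nM.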

Compound 3, half-maximal inhibitory concentration: 6500 nM
Compound 3: the middle estimate sits 1.1-fold (0.03 log units) above what was measured, and the stated range covers the measured number.
By their numbers in this assay, from the lowest: compounds 3, 1 and 2 (each within the scatter of the next).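

In this assay, among these compounds, the first measured step at this aromatic carbon is a 1.0-fold lower number from compound 1 to compound 3 (0.01 log units; within the scatter), and it comes from chloro in place of pentyloxy. The change is a large one in the terms counted here: a chain of 6 heavy atoms with 1 hydrogen-bond acceptor gives way to a single chlorine atom with no hydrogen-bond acceptor, yet the step stays within the scatter, so for this pair the pentyloxy chain can be given up with no distinguishable difference in the cytotoxicity read-out. Nothing available accounts for this flat outcome, so it stands as an observation without an explanation.

Two chemically distant groups at this place give numbers within the scatter of each other, but that pair alone does not show whether the position tolerates substitution in general or whether this assay would respond to other groups there. Going by these compounds, whether a longer chain such as octyloxy, an amine or a carboxylic acid on this aromatic carbon would also stay within the scatter, or would move the number beyond it, remains open.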